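A few compounds are considered here, and "the series" means these few. Any claim that something is new, unique, unknown or untested is made for them only; others in the source may bear on it.

Compound 1, `CC(C)COC(=O)Nc1ccc([Se][Se]c2ccc(NC(=O)OCC(C)C)cc2)cc1`: in a functional assay on PC-3 cells (Homo sapiens) for cytotoxicity, read by MTT assay, with a stated time of 72 h (a higher number here means a weaker inhibitor of growth, a lower number a stronger inhibitor of growth), compound 1 gives 24200 nM
Compound 2, `CCCOC(=O)Nc1ccc([Se]C#N)cc1`: in this assay compound 2 gives 21100 nM
Compound 3, `CC(C)COC(=O)Nc1ccc([Se]C#N)cc1`: in this assay compound 3 gives 21600 nM

All three carry a carbamate on the shared core, and all three numbers lie close together. Compound 3 sits within the scatter of compound 2 and of compound 1 alike, so the three cannot be told apart on these numbers. For the measured compounds named here, the only measured step, a 1.0-fold higher number from compound 2 to compound 3 (0.01 log units; within the scatter), changed the carbamate chain by a single methyl and moved the number hardly at all.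

Compound 4, `CCCCCCOC(=O)Nc1ccc([Se]C#N)cc1`, differs from compound 3 in the same chain: pentyl in place of isopropyl on a saturated chain carbon bound to an oxygen next to a carbonyl group. Going by the values given here, only that one small step bears on this change, and it was within the scatter. The chain now grows by more than it did in that step, but nothing measured here points to a change in either direction. The expected step in this assay is therefore a 1.1-fold lower number from compound 3 to compound 4 (0.03 log units; within the scatter), no larger than the scatter. For compound 4 the estimate in this assay is 20000 nM, with a range from 8000 nM to 50000 nM.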

Compound 4, concentration for 50% growth inhibition: 17300 nM
For compound 4 the middle estimate is 1.2-fold (0.06 log units) above the measured one; measured number inside the range.
By their numbers in this assay, from the lowest: compounds 4, 2, 3 and 1 (each within the scatter of the next).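

The earlier compounds shown here tested only a single added methyl in the carbamate chain, whereas this change is larger: pentyl in place of isopropyl on a saturated chain carbon bound to an oxygen next to a carbonyl group gives a 1.2-fold lower number from compound 3 to compound 4 (0.10 log units; within the scatter) in this assay. The second comparison, propyl in place of hydrogen on a saturated chain carbon, three bonds along the chain from an oxygen next to a carbonyl group, gives a 1.2-fold lower number from compound 2 to compound 4 (0.09 log units; within the scatter), so both larger changes stay within the scatter, and chain size at this position has no readable effect across these compounds. Nothing available here explains this result.

Still open, on these data alone, is whether a longer chain than hexyl would move the number beyond the scatter. As far as these compounds go, a chain ending in an amine or a carboxylic acid, or a phenyl ring at this position, also remains untested by these compounds.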